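This account rests on a few compounds, and the source may have more. Where it says the series, first, only, none or still open, it means among the compounds named here.

Measured compounds:
compound 1, `COc1nc(C)c(Nc2nc(Cl)cn([C@H](CO)C3CC3)c2=O)cc1C`, in an assay on frontal cortex for displacement of a labelled ligand from corticotropin-releasing factor receptor 1 (Rattus norvegicus), with a stated time of 2 h; a higher number here means a weaker inhibitor, a lower number a stronger inhibitor: 88 nM
compound 2, `COc1nc(C)c(Nc2nc(Cl)cn([C@H](COC(=O)c3cccnc3)C3CC3)c2=O)cc1C`, in this assay: 5.2 nM
compound 3, `COc1nc(C)c(Nc2nc(Cl)cn([C@H](COC(=O)Nc3ccccc3)C3CC3)c2=O)cc1C`, in this assay: 1.5 nM

Compound 3 gives the lowest of the three numbers. Its nearest neighbour is compound 2, with a 3.5-fold lower number from compound 2 to compound 3 (0.54 log units; beyond the scatter), and the furthest is compound 1, with a 59-fold lower number from compound 1 to compound 3 (1.77 log units; beyond the scatter). The earlier step of a 17-fold lower number from compound 1 to compound 2 (1.23 log units; beyond the scatter) shows the same direction: replacing the hydrogen on the oxygen at the saturated carbon with a carbonyl-linked group lowers the number sharply, and the carbamate does so more than the ester.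

Compound 4, `COc1nc(C)c(Nc2nc(Cl)cn([C@H](COC(=O)Nc3ccc(Cl)cc3)C3CC3)c2=O)cc1C`, differs from compound 3 by chloro in place of hydrogen on an aromatic carbon, on an aromatic carbon of a six-membered aromatic ring of carbon only. Going by the values given here, no measured step touches this ring; the three steps seen concern the group attached to the oxygen and what sits on the carbonyl carbon. The step from compound 2 to compound 3 indicates that the aryl part matters modestly, but nothing shown tells whether a chloro on it helps or hurts. A step within the scatter, or a small gain at most, is expected.

Compound 4 is therefore estimated at 1.2 nM, with a range of 0.4 nM to 4 nM. The expected step is a 1.3-fold lower number from compound 3 to compound 4 (0.10 log units; within the scatter).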

Compound 4, half-maximal inhibitory concentration: 1.6 nM
Beside the measured number, compound 4's estimate is 1.3-fold (0.12 log units) below it; the measured number falls inside the stated range.
By their numbers in this assay, from the lowest: compounds 3 and 4 (each within the scatter of the next); then compound 2; then compound 1.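

In this assay, going by these compounds alone, the para place on the phenyl ring of the carbamate takes a chloro with no readable effect: a 1.1-fold higher number from compound 3 to compound 4 (0.03 log units; within the scatter) stays within the scatter, so compound 3 and compound 4 cannot be told apart, and this is the first reading on that ring, where the earlier steps concerned only the group on the oxygen and what sits on the carbonyl carbon. The carbamate's standing over the other two compounds survives the chloro, with a 3.3-fold lower number from compound 2 to compound 4 (0.51 log units; beyond the scatter) against the pyridin-3-yl ester and a 55-fold lower number from compound 1 to compound 4 (1.74 log units; beyond the scatter) against the free hydroxyl, so on these compounds the (4-chlorophenyl)carbamoyl group serves as well as the phenylcarbamoyl group. Nothing available gives a reason for this flat result.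

Still open, as far as these compounds go, is whether the same place accepts a methoxy, an amine or a carboxylic acid as readily as a chloro, and whether a chloro elsewhere on the ring reads the same. Also open, from the compounds shown here alone, is whether a longer chain between the carbamate nitrogen and the phenyl ring would hold these numbers.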